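This account rests on a few compounds, and the source may have more. Where it says the series, first, only, none or still open, it means among the compounds named here.

Series notes. Three compounds share one core and differ only in the aryl group attached to it. Compound 1 `CCOC(=O)c1cnc(-c2cnc3ccccc3c2)nc1NN1C(=O)C=C(C)C1=O` carries quinolin-3-yl, and in a functional assay on Jurkat cells for inhibition of nuclear factor NF-kappa-B complex (Homo sapiens) (a lower number here means a stronger inhibitor, a higher number a weaker inhibitor), compound 1 gives 6000 nM. Compound 2 `CCOC(=O)c1cnc(-c2ccc(OC)cc2)nc1NN1C(=O)C=C(C)C1=O` carries 4-methoxyphenyl, and in this assay compound 2 gives 900 nM. Within the data shown here, compound 3 `CCOC(=O)c1cnc(-c2ccc(Cl)cc2)nc1NN1C(=O)C=C(C)C1=O` carries 4-chlorophenyl, and in this assay compound 3 gives 300 nM, the lowest number of the three measured so far. The measured steps are a 6.7-fold lower number from compound 1 to compound 2 (0.82 log units; beyond the scatter), a 20-fold lower number from compound 1 to compound 3 (1.30 log units; beyond the scatter) and a 3.0-fold lower number from compound 2 to compound 3 (0.48 log units; beyond the scatter).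

The step now followed leads to compound 4 `CCOC(=O)c1cnc(-c2cccc([N+](=O)[O-])c2)nc1NN1C(=O)C=C(C)C1=O`: 3-nitrophenyl in place of 4-chlorophenyl on an aromatic carbon. Among the measured compounds shown here, no measured step exchanges a chloro for a nitro group, and none alters a single-ring aryl group in the way compound 4 does, so the earlier steps bear on it only indirectly. Both single-ring aryl groups gave lower numbers than the bicyclic group of compound 1, as seen in a 6.7-fold lower number from compound 1 to compound 2 (0.82 log units; beyond the scatter) and a 20-fold lower number from compound 1 to compound 3 (1.30 log units; beyond the scatter), and the exchange of one substituent for another in a 3.0-fold lower number from compound 2 to compound 3 (0.48 log units; beyond the scatter) was modest. A change of about that size is expected here, more likely toward a higher number than a lower one, with wide uncertainty. For compound 4 in this assay the estimate is 600 nM, with a range from 150 nM to 3000 nM. That estimate corresponds to an expected step of a 2.0-fold higher number from compound 3 to compound 4 (0.30 log units; within the scatter).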

Compound 4, half-maximal inhibitory concentration: 7000 nM
Beside the measured number, compound 4's estimate is 12-fold (1.07 log units) below it; measured number outside the range, above it.
By their numbers in this assay, from the lowest: compound 3; then compound 2; then compounds 1 and 4 (each within the scatter of the next).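

At this position a single-ring aryl group does not by itself give a low number: in this assay, the exchange of 4-chlorophenyl for 3-nitrophenyl is a large loss, a 23-fold higher number from compound 3 to compound 4 (1.37 log units; beyond the scatter), and the exchange of 4-methoxyphenyl for 3-nitrophenyl also goes the same way, a 7.8-fold higher number from compound 2 to compound 4 (0.89 log units; beyond the scatter). The earlier advantage of both single-ring groups over quinolin-3-yl therefore does not extend to 3-nitrophenyl, since the step to it from the bicyclic group, a 1.2-fold higher number from compound 1 to compound 4 (0.07 log units; within the scatter), stays within the scatter and places compound 1 and compound 4 level. The series thus tolerates 4-chlorophenyl and 4-methoxyphenyl at this position to differing degrees, but the aryl substituent can cancel their whole gain, and nothing available here accounts for that loss.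

Compound 4 differs from compound 3 in both the substituent and its place on the phenyl ring, so the two contributions stay unseparated; a 4-nitrophenyl or a 3-chlorophenyl group would divide them, and unsubstituted phenyl would give a reference for all the substituents. Also open, from the compounds shown here alone, is whether this order of aryl groups would hold if the ethoxycarbonyl group gave way to a carboxylic acid or an amide.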